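Swapping fluoro for phenyl on the boron-bearing core

A few compounds are considered here, and "the series" means these few. Any claim that something is new, unique, unknown or untested is made for them only; others in the source may bear on it.

Measured compounds:
- compound 1, `Fc1ccc([B-]2(c3ccc(F)cc3)[NH2+]CCO2)cc1`, 17000 nM
- compound 2, `Fc1ccc([B-]2(c3ccccc3)[NH2+]CCO2)cc1`, 18800 nM

For the measured compounds named here, in an assay on HEK293 cells for inhibition of transient receptor potential cation channel subfamily V member 6 (Homo sapiens), read by FLIPR and calcium flux, with a stated time of 5 min (on this read-out lower numbers stand for stronger inhibition and higher numbers for weaker inhibition), compound 2 gives 18800 nM, the higher of the two numbers measured so far, while compound 1 gives 17000 nM; the two lie within the scatter of each other, so neither can be called the more potent.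

Compound 3, `c1ccc(-c2ccc([B-]3(c4ccccc4)[NH2+]CCO3)cc2)cc1`, has not yet been measured. It differs from compound 2 in one place: phenyl in place of fluoro on an aromatic carbon.

Going by the values given here, only one step has been measured, a 1.1-fold higher number from compound 1 to compound 2 (0.04 log units; within the scatter), and it concerns removing a fluoro from one of the two rings on boron rather than adding a phenyl. It shows that fluoro versus hydrogen at that position hardly changes the number, but it says nothing about a group as large as phenyl. Among the compounds with values here, the expectation therefore rests on little: the shared core appears tolerant of a small change at this position, and a phenyl ring is a much larger addition with no measured precedent.

For compound 3 the estimate is a modest shift toward a lower number, a 1.6-fold lower number from compound 2 to compound 3 (0.19 log units; within the scatter), giving an expected value of 12000 nM with a wide range from 3000 nM to 45000 nM.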

Compound 3, half-maximal inhibitory concentration: 72300 nM
For compound 3 the middle estimate is 6.0-fold (0.78 log units) below the measured one; the whole stated range lies below it.
By their numbers in this assay, from the lowest: compounds 1 and 2 (each within the scatter of the next); then compound 3.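

In this assay, the step of a 3.8-fold higher number from compound 2 to compound 3 (0.58 log units; beyond the scatter) shows that this position, on an aromatic carbon para to a large group, does respond to what is placed on it: trading fluoro for phenyl moves the number towards weaker inhibition, beyond the scatter. The earlier step, a 1.1-fold higher number from compound 1 to compound 2 (0.04 log units; within the scatter), stayed within the scatter and so gave no sign of this; it showed only that hydrogen in place of fluoro on one of the rings makes no clear difference, whereas here a single fluorine atom gives way to a whole phenyl ring of 6 carbons. Nothing available explains why the number rises with this change.

The compounds shown leave open how a methyl group, a methoxy group, an amine or a carboxylic acid at this same place would compare with fluoro and phenyl. For the compounds shown here, with phenyl as the only large group here, they also leave open whether the rise belongs to phenyl itself or would also appear with a propyl chain.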